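The compounds below may be only part of what the source reports. "The series", "measured", "known", "first", "only" and "open" are said of these compounds alone.

Within the data shown here, compound 2 `C[C@H]1[C@H](NCc2ccc(Cl)s2)C[C@H]2C[C@@H]1C2(C)C` gives 25000 nM in an ADME assay on MDCK cells (Canis lupus familiaris) for cytotoxicity, read by microscopy, with a stated time of 48 h (a higher number here means that more compound is tolerated, a lower number that less compound is tolerated), the lower of the two numbers measured so far; the nearest is compound 1 `C[C@H]1[C@H](NCc2ccsc2)C[C@H]2C[C@@H]1C2(C)C`, which gives 50000 nM, and the gap lies within the scatter. Among the measured compounds shown here, the one measured step, a 2.0-fold lower number from compound 1 to compound 2 (0.30 log units; within the scatter), swaps the aromatic group on the same carbon and stays within the scatter. Compound 3 `Cc1csc(CN[C@@H]2C[C@H]3C[C@@H]([C@H]2C)C3(C)C)c1` differs from compound 2 by 4-methylthiophen-2-yl in place of 5-chlorothiophen-2-yl on a saturated chain carbon bound to an amine nitrogen. For the measured compounds named here, only that single step bears here, so no movement beyond the scatter is expected in this assay. For compound 3 the estimated value is 30000 nM, with a range from 12000 nM to 80000 nM. The expected step is a 1.2-fold higher number from compound 2 to compound 3 (0.08 log units; within the scatter).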

Compound 3, minimum cytotoxic concentration: 12500 nM
Beside the measured number, compound 3's estimate is 2.4-fold (0.38 log units) above it, and the stated range covers the measured number.
By their numbers in this assay, from the lowest: compounds 3, 2 and 1 (each within the scatter of the next, the first and the last beyond it).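

In this assay the change on a saturated chain carbon bound to an amine nitrogen gives a 2.0-fold lower number from compound 2 to compound 3 (0.30 log units; within the scatter) and so does not separate 4-methylthiophen-2-yl from 5-chlorothiophen-2-yl. Among these compounds, the other new comparison gives a 4.0-fold lower number from compound 1 to compound 3 (0.60 log units; beyond the scatter) and is the first step at this position to pass the scatter, so the aromatic group here can shift the tolerated concentration, if only modestly. Nothing available accounts for this shift. Still open, as far as these compounds go, is whether a phenyl ring, a carboxylic acid or a longer chain at this place would move the number further.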